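A few compounds are considered here, and "the series" means these few. Any claim that something is new, unique, unknown or untested is made for them only; others in the source may bear on it.

Of the compounds shown here, three have been measured in an assay on a protein complex for inhibition of CDK8/Cyclin C (Homo sapiens), with a stated time of 1 h; a lower number here means a stronger inhibitor, a higher number a weaker inhibitor. Compound 2, `O=C(O)/C=C/c1ccncc1-c1ccc2ccccc2c1`, gives 5 nM. Compound 1, `CNC(=O)/C=C/c1ccncc1-c1ccc2ccccc2c1`, differs from it in one place, (methylamino in place of hydroxy on a carbonyl carbon), and in this assay compound 1 gives 12.4 nM; that change produced a 2.5-fold higher number from compound 2 to compound 1 (0.39 log units; beyond the scatter). Compound 3, `Cn1ccc2cc(-c3cnccc3/C=C/C(=O)O)ccc21`, carries a different core; the difference between the two cores is not broken down here. In this assay compound 3 gives 26.8 nM, the highest of the three numbers, above compound 1 and further above compound 2.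

Compound 4, `CNC(=O)/C=C/c1ccncc1-c1ccc2c(ccn2C)c1`, is not yet measured. It stands to compound 3 as compound 1 stands to compound 2: the change is methylamino in place of hydroxy on a carbonyl carbon, and its place is described in exactly the same words as the earlier one, so it is the same change, seen now on the core of compound 3 rather than on the core of compound 2.

Among the compounds shown this change occurs twice, and only one of the two occurrences has been measured. The expectation for compound 4 therefore rests on a single earlier step. Because the earlier change gave a 2.5-fold higher number from compound 2 to compound 1 (0.39 log units; beyond the scatter), compound 4 is expected to sit above compound 3 by a step of about a 2.4-fold higher number from compound 3 to compound 4 (0.38 log units; beyond the scatter) in this assay. The estimate for compound 4 is 65 nM, expected to lie somewhere between 30 nM and 140 nM, with the width reflecting that the earlier step was modest and that the core of compound 3 may not carry the change identically.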

Compound 4, half-maximal inhibitory concentration: 77.6 nM
Compound 4: the middle estimate sits 1.2-fold (0.08 log units) below what was measured, within the range that was stated.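

In this assay the exchange of hydroxy for methylamino on a carbonyl carbon gave a 2.9-fold higher number from compound 3 to compound 4 (0.46 log units; beyond the scatter) on the core of compound 3, so the change from carboxy to methylcarbamoyl raised the number on this core as it had on the core of compound 2. The two steps agree in direction, and their sizes cannot be told apart: the same change on two cores in this assay, a 2.5-fold higher number (0.39 log units; beyond the scatter) from compound 2 to compound 1 and a 2.9-fold higher number (0.46 log units; beyond the scatter) from compound 3 to compound 4, 1.2-fold (0.07 log units) apart, within the scatter of two such steps. Among these compounds, this shows that, for these two cores, the change carried from one to the other with its size intact, but it rests on only two matched pairs and does not show that it would carry the same way to any further core, nor does it explain why the number rises on either core.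

The compounds shown hold only the carboxylic acid and the methyl amide at this place, so it remains open whether a primary amide, a longer alkyl amide or a methyl ester would follow the same course on both cores. Also open, going by these compounds, is whether a saturated chain in place of the 2-carboxyethenyl chain would leave the step unchanged, and which parts of the two cores account for the gap between them.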